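The compounds below may be only part of what the source reports. "The series", "measured", "known", "first", "only" and "open" are said of these compounds alone.

Three analogues sharing one core have been tested in a functional assay on NCI-H1299 cells (Homo sapiens) for inhibition, read by CCK-8 assay, with a stated time of 72 h, tested at 1 uM; on this read-out higher numbers stand for a stronger effect at the one concentration tested and lower numbers for a weaker effect. Compound 1 `CN(C)C(=O)c1cc2cnc(Nc3ccc(S(=O)(=O)NCCCN=C=S)cc3)nc2n1C1CCCC1` gives 41.3%, compound 2 `CN(C)C(=O)c1cc2cnc(Nc3ccc(S(=O)(=O)NCCCCN=C=S)cc3)nc2n1C1CCCC1` gives 29.9%, and compound 3 `CN(C)C(=O)c1cc2cnc(Nc3ccc(NC(=O)CCCN=C=S)cc3)nc2n1C1CCCC1` gives 39.7%. Among these three numbers compound 3 stands second highest; the two steps ending there are a number 1.6 percentage points lower from compound 1 to compound 3 (within the scatter) and a number 9.8 percentage points higher from compound 2 to compound 3 (within the scatter). Compound 4 `CN(C)C(=O)c1cc2cnc(Nc3ccc(NC(=O)CCCCCCN=C=S)cc3)nc2n1C1CCCC1` has not been measured. It differs from compound 3 by a group of 6 heavy atoms (4 carbon, 1 nitrogen, 1 sulfur; no ring) in place of a group of 3 heavy atoms (1 carbon, 1 nitrogen, 1 sulfur; no ring), on a saturated chain carbon, three bonds along the chain from a carbonyl carbon. Among the measured compounds shown here, the only measured step that lengthens a chain in this way is a number 11.4 percentage points lower from compound 1 to compound 2 (beyond the scatter), a modest drop for a shorter lengthening than the one from compound 3 to compound 4. A drop of at least similar size is therefore expected, though a single step is a thin basis. For compound 4 the expected value in this assay is 25%, with a range from 10% to 40%, an estimated step of a number 14.7 percentage points lower from compound 3 to compound 4 (beyond the scatter).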

Compound 4, a percentage reported as inhibition, at one concentration (the size of the read-out at that concentration, not a potency): 50.9%
Estimate against measurement, compound 4: 25.9 percentage points below, and the stated range ends below it.
By their numbers in this assay, from the lowest: compounds 2, 3, 1 and 4 (each within the scatter of the next, the first and the last beyond it).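

In this assay lengthening the chain on the amide gives a number 11.2 percentage points higher from compound 3 to compound 4 (beyond the scatter) while lengthening the chain on the sulfonamide gave a number 11.4 percentage points lower from compound 1 to compound 2 (beyond the scatter) so the longer chain does not act the same way on both linkers. Compared with the sulfonamide compounds, the long amide chain gives a number 21 percentage points higher from compound 2 to compound 4 (beyond the scatter) and a number 9.6 percentage points higher from compound 1 to compound 4 (within the scatter) and so sits clear of only the lower one. Nothing measured here explains the difference between the two linkers. As far as these compounds go, what a still longer chain on the amide would give remains open. So does the effect of an amine in place of the isothiocyanate at the chain end.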